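This account rests on a few compounds, and the source may have more. Where it says the series, first, only, none or still open, it means among the compounds named here.

Compound 3 `Cc1ccc(NC(=S)NC(=O)c2ccc(OCc3ccccc3F)cc2)cc1-c1nc2ccccc2[nH]1` gives 3070 nM in a functional assay on MGC-803 cells (Homo sapiens) for inhibition, read by MTT assay, with a stated time of 48 h (on this read-out higher numbers stand for weaker inhibition and lower numbers for stronger inhibition), the lowest of the three numbers at hand. Compound 1 `Cc1ccc(NC(=S)NC(=O)c2ccc(OCc3ccccc3)cc2)cc1-c1nc2ccccc2[nH]1` gives 60700 nM, and compound 2 `Cc1ccc(NC(=S)NC(=O)c2ccc(OCc3ccc(C(F)(F)F)cc3)cc2)cc1-c1nc2ccccc2[nH]1` gives 6500 nM. Adding fluoro to the benzyl ring gave a 20-fold lower number from compound 1 to compound 3 (1.30 log units; beyond the scatter), while adding trifluoromethyl gave a 9.3-fold lower number from compound 1 to compound 2 (0.97 log units; beyond the scatter); exchanging one for the other gave a 2.1-fold lower number from compound 2 to compound 3 (0.33 log units; beyond the scatter). Compound 4 `Cc1ccc(NC(=S)NC(=O)c2ccc(OCc3cccc(F)c3)cc2)cc1-c1nc2ccccc2[nH]1` carries the same atoms joined differently: 3-fluorophenyl in place of 2-fluorophenyl on a saturated chain carbon bound to an oxygen on an aromatic ring. Going by the values given here, no measured step moves a fluoro between positions on that ring, so the bearing of the earlier steps is indirect. A small step in this assay is therefore expected, a 1.5-fold higher number from compound 3 to compound 4 (0.17 log units; within the scatter), likely within the scatter. Compound 4 is estimated at 4500 nM, within 1500 nM to 13000 nM.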

Compound 4, half-maximal inhibitory concentration: > 100000 nM
Compound 4 ended at the assay's limit; the forecaster's own chance of this, stated with the estimate: 2%; at least 22-fold (1.34 log units) between middle value and limit.
By their numbers in this assay, from the lowest: compound 3; then compound 2; then compound 1. At a limit, above all of these: compound 4.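

Compound 4 is held at a limit, not a number: the limit of > 100000 nM in this assay, at which 1 of the 4 values shown sits. In this assay, exchanging 2-fluorophenyl for 3-fluorophenyl on the same saturated chain carbon gives an at least 32-fold higher number from compound 3 to compound 4 (1.51 log units; beyond the scatter), so the gain from fluoro seen in compound 3 depends on where the fluoro sits. The 3-fluorophenyl group also trails 4-(trifluoromethyl)phenyl, with an at least 15-fold higher number from compound 2 to compound 4 (1.18 log units; beyond the scatter), and adding fluoro to the unsubstituted ring here gives an at least 1.6-fold higher number from compound 1 to compound 4 (0.21 log units; that floor lies within the scatter), so it shows no gain. Left open is how a 2-chlorophenyl or 3-methoxyphenyl would read on that carbon. Going by these compounds, how far compound 4 lies past its limit also stays unknown.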